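This account rests on a few compounds, and the source may have more. Where it says the series, first, only, none or still open, it means among the compounds named here.

In an ADME assay on HepG2 cells (Homo sapiens) for cytotoxicity, read by luminescence, CellTiter-Glo and ATP content, with a stated time of 72 h (on this read-out lower numbers stand for an effect already at smaller amounts and higher numbers for an effect only at larger amounts of compound), compound 3 `COc1ccc(F)cc1CNCCCNc1ccnc2cc(CC(C)C)ccc12` gives 2900 nM. Among the compounds with values here, compound 2 `COc1ccc(Oc2ccc3c(NCCCNCc4cccc(OC)c4O)ccnc3c2)cc1`, with 5500 nM, lies within the scatter of that number, whereas compound 1 `CC(C)Cc1ccc2c(NCCCNCc3ccco3)ccnc2c1`, with 16000 nM, sits beyond it; the single measured step is a 5.5-fold lower number from compound 1 to compound 3 (0.74 log units; beyond the scatter). Compound 4 `COc1ccc(F)cc1CNCCCNc1ccnc2cc(Cc3ccccc3)ccc12` differs from compound 3 by phenyl in place of isopropyl on a saturated chain carbon bound to an aromatic carbon. Within the data shown here, no measured step touches this part of the molecule, so that step offers only an indirect guide, and the three values together span a narrow band. The expected step in this assay is a 1.2-fold lower number from compound 3 to compound 4 (0.06 log units; within the scatter), which would remain within the scatter. Compound 4 is therefore estimated to give about 2500 nM, with a range from 900 nM to 7000 nM.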

Compound 4, half-maximal effective concentration: 7990 nM
Beside the measured number, compound 4's estimate is 3.2-fold (0.50 log units) below it; the measured number lies above the stated range.
By their numbers in this assay, from the lowest: compounds 3, 2, 4 and 1 (each within the scatter of the next, the first and the last beyond it).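

Phenyl in place of isopropyl on a saturated chain carbon bound to an aromatic carbon gives, in this assay, a 2.8-fold higher number from compound 3 to compound 4 (0.44 log units; beyond the scatter). Within the data shown here, this shows that this position, which no earlier step touched, also moves the number beyond the scatter, and here the number rises, whereas the earlier single change at the other end of the molecule lowered it. Nothing measured here explains this rise.

The compounds shown leave open how a cyclohexyl group would read at this place, and whether the same change holds when furan-2-yl replaces 5-fluoro-2-methoxyphenyl.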